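The source may hold more compounds than are shown below. What is called first, only, known or untested is meant among the compounds shown, and "the series" means these compounds.

Compound 1 `COC(=O)c1c(-c2ccc(O)cc2)oc2ccccc2c1=O`, compound 2 `COC(=O)c1c(-c2ccc(O)cc2)oc2cc(OC)ccc2c1=O` and compound 3 `COc1cc(-c2oc3ccccc3c(=O)c2C(=O)O)cc(OC)c1OC` were tested in a functional assay on SK-MEL cells (Homo sapiens) for cytotoxicity, read by MTT assay, with a stated time of 6 days; on this read-out higher numbers stand for an effect only at larger amounts of compound and lower numbers for an effect already at smaller amounts. In this assay compound 2 gives 19.6 ug/mL. For compound 1 only a limit was reached, > 25 ug/mL. For compound 3 likewise only a limit was reached, > 25 ug/mL. How the core of compound 3 differs from that of compound 2 is not broken down here. The change hydrogen in place of methoxy on an aromatic carbon gave an at least 1.2-fold higher number from compound 2 to compound 1 (0.10 log units; that floor lies within the scatter). Compound 4 `COc1cc(OC)cc(-c2oc3ccccc3c(=O)c2C(=O)O)c1` carries the same kind of change relative to compound 3, (hydrogen in place of methoxy on an aromatic carbon), the place being ortho to two methoxy groups and para to a large group rather than meta to a fused ring and para to a fused ring. Compound 4 is expected to show a step that the limit leaves unreadable from compound 3 to compound 4 in this assay because compound 3 sits at the limit of > 25 ug/mL in this assay, at which 2 of the 3 values shown sit, and the earlier change gave an at least 1.2-fold higher number from compound 2 to compound 1 (0.10 log units; that floor lies within the scatter). Compound 4 is therefore estimated at 40 ug/mL in this assay, between 20 ug/mL and 100 ug/mL.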

Compound 4, concentration for half-maximal effect: > 25 ug/mL
Compound 4: a limit, no number; the forecaster's own chance of this, stated with the estimate: 75%; the middle value does not contradict the limit.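

No step can be read between compound 3 and compound 4, as both stop at the same limit: the limit of > 25 ug/mL in this assay, at which 3 of the 4 values shown sit.

As far as these compounds go, whether removing this methoxy group changes the effect at all in this assay remains open.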